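Chloro for Methoxy on the Aryl Group of Compound 1

This account rests on a few compounds, and the source may have more. Where it says the series, first, only, none or still open, it means among the compounds named here.

Compound 1 `COc1ccc(-c2cnc3cc4c(cc3n2)C2CNCC4C2)cc1` gives 26 nM in an assay for binding affinity to Neuronal acetylcholine receptor; alpha4/beta2 (Rattus norvegicus) (a higher number here means a weaker inhibitor, a lower number a stronger inhibitor), the highest of the three numbers at hand. For the measured compounds named here, compound 3 `Cc1ccnc2cc3c(cc12)C1CNCC3C1` gives 1.8 nM, and compound 2 `Cc1ccc2cc3c(cc2n1)C1CNCC3C1` gives 0.76 nM; both carry a methyl on a smaller core rather than the 4-methoxyphenyl of compound 1, so their values show only that compound 1 sits well above them, beyond the scatter, and no single change links them to it. Compound 4 `Clc1ccc(-c2cnc3cc4c(cc3n2)C2CNCC4C2)cc1` differs from compound 1 in one place: chloro in place of methoxy on an aromatic carbon. Going by the values given here, with no measured pair sharing this change, the step is expected to be modest, a 1.3-fold lower number from compound 1 to compound 4 (0.11 log units; within the scatter), in either direction or none beyond the scatter. Compound 4 is therefore estimated at 20 nM, within 6 nM to 70 nM.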

Compound 4, inhibition constant: 78 nM
Estimate against measurement, compound 4: 3.9-fold (0.59 log units) below; measured number outside the range, above it.
By their numbers in this assay, from the lowest: compound 2; then compound 3; then compound 1; then compound 4.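

In this assay, chloro in place of methoxy on this aromatic carbon gives a 3.0-fold higher number from compound 1 to compound 4 (0.48 log units; beyond the scatter) and so moves the number beyond the scatter. For the compounds shown here, this position, para to a large group, therefore responds to a single change, which the earlier compounds, linked by no such change, could not show. No measurement at hand accounts for the rise with chloro. On these data alone, whether a hydroxyl, an amine or a nitrile here would give a lower number than methoxy remains open. So does whether a longer ether, such as ethoxy, would keep the number of compound 1.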